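The source may hold more compounds than are shown below. What is called first, only, known or untested is meant among the compounds shown, and "the series" means these compounds.

In a functional assay on HCT-116 cells (Homo sapiens) for inhibition (on this read-out lower numbers stand for stronger inhibition and higher numbers for weaker inhibition), three compounds with a shared core differ only in the amine on a saturated chain carbon bound to an aromatic carbon. Compound 1 `CCNC(=O)c1noc(-c2cc(C(C)C)c(O)cc2O)c1-c1cc(CN)no1` gives 84 nM, compound 2 `CCCNCc1cc(-c2c(C(=O)NCC)noc2-c2cc(C(C)C)c(O)cc2O)on1` gives 117 nM, and compound 3 `CCCN(CCC)Cc1cc(-c2c(C(=O)NCC)noc2-c2cc(C(C)C)c(O)cc2O)on1` gives 183 nM. Compound 3 thus lies within the scatter of compound 2 and is clear of compound 1 only. Going by the values given here, the sole step beyond the scatter is modest, a 2.2-fold higher number from compound 1 to compound 3 (0.34 log units; beyond the scatter), while a 1.4-fold higher number from compound 1 to compound 2 (0.14 log units; within the scatter) and a 1.6-fold higher number from compound 2 to compound 3 (0.19 log units; within the scatter) both stay within it.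

Compound 4 `CCNC(=O)c1noc(-c2cc(C(C)C)c(O)cc2O)c1-c1cc(CN2CCCCC2)no1` has not yet been measured. It carries piperidin-1-yl in place of dipropylamino on a saturated chain carbon bound to an aromatic carbon. Among the compounds with values here, no measured compound has a ring at this place, so the evidence is indirect: the three steps above are the only guide, and all are small. No shift beyond the scatter is therefore expected, and the estimated step is a 1.2-fold lower number from compound 3 to compound 4 (0.09 log units; within the scatter). For compound 4 the expected value is 150 nM, with an estimated range of 70 nM to 320 nM.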

Compound 4, half-maximal inhibitory concentration: 93 nM
Beside the measured number, compound 4's estimate is 1.6-fold (0.21 log units) above it, within the range that was stated.
By their numbers in this assay, from the lowest: compounds 1, 4, 2 and 3 (each within the scatter of the next, the first and the last beyond it).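

In this assay, the place on a saturated chain carbon bound to an aromatic carbon now holds a ring as well as open-chain amines, and piperidin-1-yl stays within the scatter of all three, with a 2.0-fold lower number from compound 3 to compound 4 (0.29 log units; within the scatter) and a 1.3-fold lower number from compound 2 to compound 4 (0.10 log units; within the scatter) and also a 1.1-fold higher number from compound 1 to compound 4 (0.04 log units; within the scatter) at this place. Compound 4 therefore cannot be told apart from either compound 1 or compound 3, even though those two are separated by a 2.2-fold higher number from compound 1 to compound 3 (0.34 log units; beyond the scatter) on this read-out. Nothing available explains these numbers. It remains open whether pyrrolidin-1-yl, with a smaller ring, or morpholin-4-yl, with a second hetero atom in the ring, would also stay within the scatter of these compounds. On these data alone, a carboxylic acid on the same chain carbon is equally open.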